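Aryl-oxadiazole imidazolines: replacing the phenoxy tail

The compounds below may be only part of what the source reports. "The series", "measured", "known", "first", "only" and "open" are said of these compounds alone.

The series shares a core in which an imidazoline-bearing phenyl is joined through an oxadiazole to an outer aromatic ring. Compound 2 (`c1ccc(Oc2ccc(-c3noc(-c4ccc(C5=NCCN5)cc4)n3)cc2)cc1`) carries a phenoxy group on that outer ring; compound 1 (`c1ccc(OCc2noc(-c3ccc(C4=NCCN4)cc3)n2)cc1`) instead connects a phenoxy through a methylene to the oxadiazole. Among the measured compounds shown here, in an assay for inhibition of Amine oxidase [flavin-containing] A (Homo sapiens), read by fluorescence and spectrophotometry, using microsomes, with stated times of 30 min and 20 min (on this read-out lower numbers stand for stronger inhibition and higher numbers for weaker inhibition), compound 2 gives 2770 nM, the only numerical value recorded so far. For compound 1 the same assay reports only a limit, > 100000 nM, so it stands as a limit and not as a number; in short, (the limit of > 100000 nM in this assay, at which 1 of the 2 values shown sits). For the measured compounds named here, no step between two measured compounds exists, so nothing measured here shows how changes at the outer ring move potency.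

Compound 3 (`Cn1ccnc1SCc1ccc(-c2noc(-c3ccc(C4=NCCN4)cc3)n2)cc1`) differs from compound 2 in one place: ((1-methyl-1H-imidazol-2-yl)sulfanyl)methyl in place of phenoxy on an aromatic carbon. Going by the values given here, with no measured step to lean on, the expectation is a modest loss, somewhat beyond the scatter, the step from compound 2 to compound 3 being estimated as a 2.2-fold higher number from compound 2 to compound 3 (0.34 log units; beyond the scatter). Compound 3 is therefore expected to give about 6000 nM, within a range from 1500 nM to 25000 nM, with a real chance that only a limit is returned.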

Compound 3, half-maximal inhibitory concentration: 12400 nM
Compound 3: the middle estimate sits 2.1-fold (0.32 log units) below what was measured; the measured number falls inside the stated range.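

Among the compounds shown here, this is the first readable step: in this assay, ((1-methyl-1H-imidazol-2-yl)sulfanyl)methyl in place of phenoxy gives a 4.5-fold higher number from compound 2 to compound 3 (0.65 log units; beyond the scatter) and so weakens inhibition beyond the scatter. The position, on an aromatic carbon para to a large group, therefore responds to what is placed there, yet it tolerates the exchange of a six-membered aromatic ring of carbon only for a five-membered aromatic ring with 2 hetero atoms without the read-out collapsing to a limit. Nothing in hand bears on what lies behind this step, and the ring, the sulfur and the methylene all change together in this single exchange.

Still open, on these data alone, is which part of the entering group carries the loss, a question that a phenylsulfanylmethyl group or an imidazolylmethyl group without the sulfur could address at the same carbon. Also open, as far as these compounds go, is whether a morpholine or a carboxylic acid there would move the number to either side of compound 2 at 2770 nM in this assay.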